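Swapping chloro for methyl: what compound 4 may show

A few compounds are considered here, and "the series" means these few. Any claim that something is new, unique, unknown or untested is made for them only; others in the source may bear on it.

Values measured so far in an ADME assay on HPC cells (Homo sapiens) for cytotoxicity, with a stated time of 24 h (a higher number here means that more compound is tolerated, a lower number that less compound is tolerated), are as follows.
- compound 1 `O=C1/C(=C/c2ccc(F)cc2)CCC/C1=C\c1ccccc1[N+](=O)[O-]` gives 11000 nM
- compound 2 `O=C1/C(=C/c2ccc(Cl)cc2)CCC/C1=C\c1ccccc1[N+](=O)[O-]` gives 400000 nM
- compound 3 `O=C1/C(=C/c2ccc(Cl)cc2)CCC/C1=C\c1cccc([N+](=O)[O-])c1` gives 18000 nM

Compound 3 (18000 nM) lies within the scatter of compound 1 (11000 nM) and well under compound 2 (400000 nM) in this assay. Compound 4 `Cc1ccc(/C=C2\CCC/C(=C\c3cccc([N+](=O)[O-])c3)C2=O)cc1` keeps the core of compound 3 but carries methyl in place of chloro on an aromatic carbon, para to a large group (methyl in place of chloro on an aromatic carbon). Going by the values given here, no measured step makes this exchange. The nearest is the exchange of chloro in place of fluoro on an aromatic carbon, a large step of a 36-fold higher number from compound 1 to compound 2 (1.56 log units; beyond the scatter). It involves other groups and another pair of compounds, so it warns that one such exchange can matter but fixes neither size nor direction here. From the compounds shown here alone, no step beyond the scatter is therefore expected, though a wide margin stays open on both sides. The expected step is a 1.2-fold lower number from compound 3 to compound 4 (0.08 log units; within the scatter). For compound 4 the estimated value is 15000 nM, with an expected range from 4000 nM to 60000 nM.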

Compound 4, half-maximal cytotoxic concentration: 192000 nM
Beside the measured number, compound 4's estimate is 13-fold (1.11 log units) below it; the whole stated range lies below it.
By their numbers in this assay, from the lowest: compounds 1 and 3 (each within the scatter of the next); then compound 4; then compound 2.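

In this assay, methyl in place of chloro on the aromatic carbon para to a large group gives an 11-fold higher number from compound 3 to compound 4 (1.03 log units; beyond the scatter), so a change of a single heavy atom at this position is enough to move the number well beyond the scatter. Going by these compounds alone, the only earlier step at this position, a 36-fold higher number from compound 1 to compound 2 (1.56 log units; beyond the scatter), had the chloro compound on the higher side, whereas here it is on the lower side, so chloro does not set the same order against its replacement in both pairs, which also differ in where the nitro group sits. No measurement shown here accounts for this reversal.

From the compounds shown here alone, whether methyl would have the same effect with the nitro group placed as in compound 2 remains open. Going by these compounds, it is also open how a methoxy group or an amine at this position would compare.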